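The compounds below may be only part of what the source reports. "The series", "measured", "known", "first", "only" and "open" are said of these compounds alone.

In a functional assay on MDA-MB-468 cells (Homo sapiens) for inhibition, read by sulforhodamine B assay, with a stated time of 48 h, tested at 10 uM (a lower number here means less inhibition, a higher number more inhibition at the concentration tested (going by the name of the read-out)), compound 2, with the structure `CC(=O)c1ccc(-c2cn3ccnc3c(-c3ccc4ncn(C5CCCCC5)c4c3)n2)cc1`, gives 0.73%, the lowest of the three numbers measured. Compound 1, `c1ccc2c(-c3cn4ccnc4c(-c4ccc5ncn(C6CCCCC6)c5c4)n3)cccc2c1`, gives 10.4%, and the step of a number 9.7 percentage points lower from compound 1 to compound 2 (within the scatter) is within the scatter, so the two cannot be ranked. Compound 3, `Fc1ccccc1-c1cn2ccnc2c(-c2ccc3ncn(C4CCCCC4)c3c2)n1`, gives 27.6%, and the step of a number 26.9 percentage points higher from compound 2 to compound 3 (beyond the scatter) is beyond the scatter, as is the step of a number 17.2 percentage points higher from compound 1 to compound 3 (beyond the scatter).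

Compound 4, `c1csc(-c2cn3ccnc3c(-c3ccc4ncn(C5CCCCC5)c4c3)n2)c1`, is not yet measured. It differs from compound 2 in one place: thiophen-2-yl in place of 4-acetylphenyl on an aromatic carbon. The measured steps that bear on this all swap the group at the same position; the only one that went beyond the scatter was the move to 2-fluorophenyl in compound 3, with a number 26.9 percentage points higher from compound 2 to compound 3 (beyond the scatter), while the move from naphthalen-1-yl to 4-acetylphenyl gave a number 9.7 percentage points lower from compound 1 to compound 2 (within the scatter). A swap to another small aromatic group is therefore expected to raise the number modestly, by about a number 14.3 percentage points higher from compound 2 to compound 4 (beyond the scatter). Compound 4 is estimated to give 15%, within a range from 0% to 35%.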

Compound 4, a percentage reported as inhibition, at one concentration (the size of the read-out at that concentration, not a potency): 15.1%
Compound 4: middle estimate off by 0.1 percentage points, on the low side, within the range that was stated.
By their numbers in this assay, from the lowest: compounds 2, 1 and 4 (each within the scatter of the next, the first and the last beyond it); then compound 3.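

In this assay, thiophen-2-yl, a five-membered aromatic ring with 5 heavy atoms, gives a number 14.4 percentage points higher from compound 2 to compound 4 (beyond the scatter) when it replaces 4-acetylphenyl, so a smaller ring holding sulfur can stand at this position on the aromatic carbon and clear the scatter against compound 2. The same group gives a number 4.7 percentage points higher from compound 1 to compound 4 (within the scatter) when it replaces naphthalen-1-yl, so those two compounds cannot be ranked, while the change from 2-fluorophenyl gives a number 12.5 percentage points lower from compound 3 to compound 4 (beyond the scatter) and leaves compound 3 clearly above all three others. Nothing measured on these compounds explains why these groups differ.

A plain phenyl group would help show whether the fluorine of compound 3 matters, or only the six-membered ring. From the compounds shown here alone, how an amine or a carboxylic acid on this ring would behave stays open.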